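Aryl amide ring nitrogen change: working notes on compound 3

This account rests on a few compounds, and the source may have more. Where it says the series, first, only, none or still open, it means among the compounds named here.

Measured compounds:
compound 1 `COc1cc2c(Oc3ccc(NC(=O)c4cc(-c5ccccc5)ccn4)cc3F)ccnc2cc1OCCCN1CCN(C)CC1` — 150 nM
compound 2 `COc1cc2c(Oc3ccc(NC(=O)c4cc(-c5ccccc5)ccn4)cc3F)ccnc2cc1OCCCN1CCCCC1` — 270 nM

In a functional assay on MKN-45 cells (Homo sapiens) for cytotoxicity, read by MTT assay, with a stated time of 72 h (on this read-out lower numbers stand for stronger inhibition and higher numbers for weaker inhibition), compound 1 gives 150 nM and compound 2 gives 270 nM. Compound 2 carries the larger of the two numbers, the gap being a 1.8-fold higher number from compound 1 to compound 2 (0.26 log units; within the scatter).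

Compound 3 `COc1cc2c(Oc3ccc(NC(=O)c4nccc(-c5ccccc5)n4)cc3F)ccnc2cc1OCCCN1CCCCC1` differs from compound 2 by 4-phenylpyrimidin-2-yl in place of 4-phenylpyridin-2-yl on a carbonyl carbon. Going by the values given here, no measured step touches this part of the molecule; the single step, a 1.8-fold higher number from compound 1 to compound 2 (0.26 log units; within the scatter), concerns the chain-end amine instead and offers no guide. With nothing bearing on the change, no step beyond the scatter is expected, so a 1.1-fold higher number from compound 2 to compound 3 (0.05 log units; within the scatter) is the working assumption. Compound 3 is therefore estimated at 300 nM in this assay, within 100 nM to 900 nM.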

Compound 3, half-maximal inhibitory concentration: 1030 nM
Beside the measured number, compound 3's estimate is 3.4-fold (0.54 log units) below it, outside the stated range (above it).
By their numbers in this assay, from the lowest: compounds 1 and 2 (each within the scatter of the next); then compound 3.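

Going by these compounds alone, the amide aryl group is the first place where one change moves the number beyond the scatter: in this assay, 4-phenylpyrimidin-2-yl in place of 4-phenylpyridin-2-yl on the carbonyl carbon gives a 3.8-fold higher number from compound 2 to compound 3 (0.58 log units; beyond the scatter). The earlier chain-end amine change, a 1.8-fold higher number from compound 1 to compound 2 (0.26 log units; within the scatter), stayed within the scatter. No available evidence accounts for the larger step.

From the compounds shown here alone, whether this ring change has a similar effect with the 4-methylpiperazin-1-yl chain end remains open. So does the effect of a morpholine at the chain end, or of an amino group on the pyrimidine ring.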